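The source may report more compounds than this note shows. Statements on the series, on what has been measured and on what is new or still open speak of the compounds shown alone.

Measured compounds in the series:

compound 1 `Nc1ccc(Nc2c(C(=O)NCc3ccc(F)cc3)nc(Br)c3cccnc23)cc1`: 10000 nM in a functional assay on HCT-116 cells (Homo sapiens) for cytotoxicity, read by MTT assay, with a stated time of 72 h; on this read-out lower numbers stand for stronger inhibition and higher numbers for weaker inhibition
compound 2 `COC(=O)c1nc(Br)c2cccnc2c1N[C@H]1CC[C@H](N)CC1`: "not determined" (no result reported) in this assay
compound 3 `N[C@H]1CC[C@H](Nc2c(C(=O)NCc3ccccn3)nc(Br)c3cccnc23)CC1`: "not determined" (no result reported) in this assay

The shared core carries an aromatic nitrogen whose substituent is the point of variation. In this assay, among the measured compounds shown here, compound 1 gives 10000 nM, and that is the only number in the set; compound 2 and compound 3 have no reported result, so nothing can be said of how they compare with compound 1, and no step between two measured compounds exists.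

Compound 4 `COC(=O)CNc1c(C(=O)NCc2ccc(F)cc2)nc(Br)c2cccnc12` is the next entry to be measured. It differs from compound 1 in one place ((methoxycarbonyl)methyl in place of 4-aminophenyl on a nitrogen on an aromatic ring). For the measured compounds named here, since no measured pair shows what a change at this nitrogen does, the expectation rests on compound 1 alone, which sits at the weak end of what this read-out usually reports.

The step from compound 1 to compound 4 is expected to be small, no change at the digits printed from compound 1 to compound 4 (within the scatter), with no direction beyond the scatter that can be justified from the data. Compound 4 is therefore estimated at 10000 nM in this assay, within a range of 4000 nM to 30000 nM, and a result given only as a limit would not be surprising.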

Compound 4, half-maximal inhibitory concentration: > 10000 nM
Compound 4: no number, only a limit; the forecaster's own chance of this, stated with the estimate: 40%; the middle value lies on the limit itself.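

In this assay, compound 4 gives only a limit, > 10000 nM, and not a number. Among the compounds shown here, this is the first change at this nitrogen that can be read at all: replacing 4-aminophenyl with (methoxycarbonyl)methyl gives a number no lower from compound 1 to compound 4 (the limit leaves the size open), so swapping the six-membered aromatic ring of carbon for a chain with no ring produces no measurable gain in this read-out. The limit also sets how far the comparison can go, since the size of the step stays unknown and neither substituent can be ranked against the other: the limit of > 10000 nM in this assay, at which 1 of the 4 values shown sits.

Whether any substituent on this nitrogen can bring the series to a lower number remains open, as the compounds shown give no value on the stronger side of the read-out. The carboxylic acid matching the methyl ester, a longer chain ending in an amine, and a small alkyl group such as methyl on this nitrogen all remain untested among the compounds shown, so the effect of each at this position in this assay is unknown.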